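Compound 3 to compound 4: pyrrolyl gives way to imidazolyl

The source may hold more compounds than are shown below. What is called first, only, known or untested is meant among the compounds shown, and "the series" means these compounds.

Measured in a functional assay on A549 cells (Homo sapiens) for antiproliferative activity, read by MTT assay, with a stated time of 48 h; a higher number here means a weaker inhibitor, a lower number a stronger inhibitor:
- Compound 1 `Cn1cc(C2=C(c3nn(CCCn4cncn4)c4ncccc34)C(=O)N(c3ccccc3)C2=O)c2ccccc21`: > 100000 nM (a limit)
- Compound 2 `Cn1cc(C2=C(c3nn(CCCn4ccnc4)c4ncccc34)C(=O)N(c3ccccc3)C2=O)c2ccccc21`: 1560 nM
- Compound 3 `Cn1cc(C2=C(c3nn(CCCn4cccc4)c4ncccc34)C(=O)N(c3ccccc3)C2=O)c2ccccc21`: > 100000 nM (a limit)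

Compound 3 gives > 100000 nM in this assay, and this is a limit, not a number. It shares that position with compound 1, as the limit of > 100000 nM in this assay, at which 2 of the 3 values shown sit, records. Only compound 2 has a measured number, 1560 nM.

Compound 4 `Cn1cc(C2=C(c3nn(CCCCn4ccnc4)c4ncccc34)C(=O)N(c3ccccc3)C2=O)c2ccccc21` departs from compound 3 by this change: (1H-imidazol-1-yl)methyl in place of 1H-pyrrol-1-yl on a saturated chain carbon, three bonds along the chain from an aromatic nitrogen. In words, (1H-imidazol-1-yl)methyl stands in place of 1H-pyrrol-1-yl on a saturated chain carbon, three bonds along the chain from an aromatic nitrogen. Cut one bond further out, 3-(1H-pyrrol-1-yl)propyl becomes 4-(1H-imidazol-1-yl)butyl.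

Within the data shown here, two measured steps bear on this. With 1H-pyrrol-1-yl in place of 1H-imidazol-1-yl, the data show an at least 64-fold higher number from compound 2 to compound 3 (1.80 log units; beyond the scatter), a large step beyond the scatter. With 1H-imidazol-1-yl in place of 1H-1,2,4-triazol-1-yl, they show an at least 64-fold lower number from compound 1 to compound 2 (1.80 log units; beyond the scatter), also large. Among the measured compounds shown here, no measured compound carries the 4-(1H-imidazol-1-yl)butyl group, so the expectation rests on compound 2 alone, at 1560 nM.

A large step towards a lower number is therefore expected, estimated as an at least 40-fold lower number from compound 3 to compound 4 (1.60 log units; beyond the scatter). Compound 4 is estimated at 2500 nM, with an expected range of 500 nM to 12000 nM.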

Compound 4, half-maximal inhibitory concentration: 21700 nM
Beside the measured number, compound 4's estimate is 8.7-fold (0.94 log units) below it; measured number outside the range, above it.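

Compound 4 shows that an imidazolyl group still gives a measured number in this assay on the 4-(1H-imidazol-1-yl)butyl chain, with an at least 4.6-fold lower number from compound 3 to compound 4 (0.66 log units; beyond the scatter) and an at least 4.6-fold lower number from compound 1 to compound 4 (0.66 log units; beyond the scatter). It also shows something compounds 1 to 3, which share one chain length, could not: the chain length itself counts, since replacing 3-(1H-imidazol-1-yl)propyl with 4-(1H-imidazol-1-yl)butyl gives a 14-fold higher number from compound 2 to compound 4 (1.14 log units; beyond the scatter). The steps from compound 1 and compound 3 give only minimum sizes, because each of those compounds stands at a limit and not at a number: the limit of > 100000 nM in this assay, at which 2 of the 4 values shown sit.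

From the compounds shown here alone, whether the number keeps rising with a pentyl chain, or how an ethyl chain carrying imidazolyl would compare, stays open, as does whether 1H-pyrrol-1-yl or 1H-1,2,4-triazol-1-yl would give a measured number on the butyl chain. Also open, going by these compounds, is how an amine such as morpholine or dimethylamino at the end of the chain would compare with imidazolyl.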